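The source may report more compounds than this note shows. Statements on the series, on what has been measured and on what is new or still open speak of the compounds shown alone.

Among the measured compounds shown here, compound 3 `Cc1cccc(-n2nncc2CN2C(=O)C3(C(C#N)=C(N)Oc4c(N)cc5nc6ccccc6nc5c43)c3ccccc32)c1` is the only compound here with a real number in a functional assay on A549 cells (Homo sapiens) for antiproliferative activity, read by MTT assay, with a stated time of 48 h; a lower number here means a stronger inhibitor, a higher number a weaker inhibitor: compound 3 gives 12300 nM. Compound 1 `COc1ccccc1-n1nncc1CN1C(=O)C2(C(C#N)=C(N)Oc3c2c2nc4ccccc4nc2c2ccccc32)c2ccccc21` stops at the limit in this assay, where compound 1 gives > 50000 nM. Compound 2 `CC(=O)Nc1ccc(-n2nncc2CN2C(=O)C3(C(C#N)=C(N)Oc4c3c3nc5ccccc5nc3c3ccccc43)c3ccccc32)cc1` likewise stops at the limit in this assay, where compound 2 gives > 50000 nM. The step that the two limits leave unreadable from compound 1 to compound 2 therefore shows no size, because both of its ends sit at the limit of > 50000 nM in this assay, at which 2 of the 3 values shown sit. Compound 4 `Cc1ccc(Cl)cc1-n1nncc1CN1C(=O)C2(C(C#N)=C(N)Oc3c(N)cc4nc5ccccc5nc4c32)c2ccccc21` is not yet measured; it differs from compound 3 in one place: 5-chloro-2-methylphenyl in place of 3-methylphenyl on an aromatic nitrogen. For the measured compounds named here, no measured step speaks to this kind of exchange on an aromatic nitrogen: the only step that alters that group, a step that the two limits leave unreadable from compound 1 to compound 2, is unreadable. There is thus no basis for expecting a step beyond the scatter in this assay in either direction, and the estimate simply stays near compound 3. Compound 4 is expected to give about 12000 nM, within a range from 4000 nM to 40000 nM. The step of a 1.0-fold lower number from compound 3 to compound 4 (0.01 log units; within the scatter) that this implies is expected to remain within the scatter.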

Compound 4, half-maximal inhibitory concentration: > 50000 nM
Compound 4: no number, only a limit (the forecaster's own chance of this, stated with the estimate: 25%); middle value at least 4.1-fold (0.61 log units) away from the limit.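

Among the compounds shown here, this is the first readable step for an exchange on this aromatic nitrogen: in this assay, 5-chloro-2-methylphenyl in place of 3-methylphenyl gives an at least 4.0-fold higher number from compound 3 to compound 4 (0.60 log units; beyond the scatter). Exchanges of the aryl group at this position can therefore cost activity in a way that exceeds the scatter, which the unreadable step between compound 1 and compound 2 could not show. This step is only a minimum, because compound 4 stops at a limit of the assay and not at a real number: the limit of > 50000 nM in this assay, at which 3 of the 4 values shown sit.

The exchange both adds a chlorine and alters where the methyl sits, so the compounds shown cannot say which of the two matters. They also leave open whether a plain phenyl or a phenyl bearing an amine here would give a lower number than compound 3, which gives 12300 nM.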